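The source may hold more compounds than are shown below. What is called first, only, known or untested is meant among the compounds shown, and "the series" means these compounds.

Among the measured compounds shown here, compound 1 `c1ccc(CNCC2CCN(CCCc3c[nH]c4ccc(-n5cnnc5)cc34)CC2)cc1` is one of two compounds measured in an assay on CHO cells for agonist activity at 5-hydroxytryptamine receptor 1D (Homo sapiens), read by GTPgammaS binding; on this read-out higher numbers stand for an effect only at larger amounts of compound and lower numbers for an effect already at smaller amounts. In this assay compound 1 gives 5.6 nM, the lowest of the two numbers. For the measured compounds named here, the other measured compound, compound 2 `C[C@H](NC1CCN(CCCc2c[nH]c3ccc(-n4cnnc4)cc23)CC1)c1ccccc1`, gives 12 nM in this assay; the single measured step, a 2.1-fold higher number from compound 1 to compound 2 (0.33 log units; beyond the scatter), came from putting (1-phenylethyl)amino in place of (benzylamino)methyl on a saturated ring carbon.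

Compound 3 `CC(CO)(NC1CCN(CCCc2c[nH]c3ccc(-n4cnnc4)cc23)CC1)c1ccccc1` differs from compound 1 in one place: (1-(hydroxymethyl)-1-phenylethyl)amino in place of (benzylamino)methyl on a saturated ring carbon. Going by the values given here, the step from compound 1 to compound 2 bears on this change, since in both cases the (benzylamino)methyl group gives way to an amino group that carries a phenyl-bearing carbon; compound 3 adds a hydroxymethyl and a methyl on that carbon, for which no measured pair gives guidance. A modest rise beyond the scatter, in the direction seen from compound 1 to compound 2 and perhaps somewhat larger, is therefore expected; the expected step is a 2.9-fold higher number from compound 1 to compound 3 (0.46 log units; beyond the scatter). Compound 3 is estimated at 16 nM in this assay, with a range from 5 nM to 50 nM.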

Compound 3, half-maximal effective concentration: 3.4 nM
Compound 3: middle estimate off by 4.7-fold (0.67 log units), on the high side; the measured number lies below the stated range.
By their numbers in this assay, from the lowest: compounds 3 and 1 (each within the scatter of the next); then compound 2.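

Read in this assay, putting 1-(hydroxymethyl)-1-phenylethyl in place of 1-phenylethyl on the amine nitrogen gives a 3.5-fold lower number from compound 2 to compound 3 (0.55 log units; beyond the scatter) and so shows that this group can change the number beyond the scatter, even with the rest of the molecule held the same. Set against the other compound, the same group gives a 1.6-fold lower number from compound 1 to compound 3 (0.22 log units; within the scatter) and thus leaves compound 3 level with compound 1, so the rise seen earlier with compound 2 does not hold for every amino group on this saturated ring carbon. The ring carbon, three ring bonds from the ring nitrogen, can therefore carry a group of 11 heavy atoms that includes an oxygen, with the number staying within the scatter of compound 1.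

The compounds shown leave open whether the hydroxyl itself matters or the extra carbon alone would do, and how a methoxymethyl, an aminomethyl or a carboxylic acid would behave in place of the hydroxymethyl. No measurement offered here accounts for the size or direction of these steps.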